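The compounds below may be only part of what the source reports. "The series", "measured", "known", "first", "only" and "open" are said of these compounds alone.

Measured in a functional assay on HepG2 cells (Homo sapiens) for antiproliferative activity, read by MTT assay, with a stated time of 72 h; a lower number here means a stronger inhibitor, a higher number a weaker inhibitor:
- compound 1 `COc1ccc(NC(=S)Nc2nc(C(=O)NCCCc3ccccc3)cs2)cc1`: 71300 nM
- compound 2 `CCOC(=O)c1csc2nc(CN3CCN(C)CC3)c(-c3ccc(C)cc3)n12`: 53600 nM

Compound 2 gives 53600 nM, and compound 1 gives 71300 nM. These two values lie within the usual scatter of repeated measurements, so they cannot be ranked against each other.

Compound 3 `CCOC(=O)c1csc2nc(CN3CCN(Cc4ccccc4)CC3)c(-c3ccc(C)cc3)n12` keeps the core of compound 2 and differs in one place: phenyl in place of hydrogen on a saturated chain carbon bound to an amine nitrogen in a ring. This is phenyl in place of hydrogen on a saturated chain carbon bound to an amine nitrogen in a ring, which turns methyl into benzyl. Going by the values given here, no measured pair shows a change of this kind, so the size of the step cannot be read from the data. A modest move towards a lower number in this assay is expected, and it may not clear the scatter. The estimated change is a 1.8-fold lower number from compound 2 to compound 3 (0.25 log units; within the scatter). The expected value for compound 3 is 30000 nM, with an estimated range from 9000 nM to 80000 nM.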

Compound 3, half-maximal inhibitory concentration: 88200 nM
Compound 3: middle estimate off by 2.9-fold (0.47 log units), on the low side, and the stated range ends below it.
By their numbers in this assay, from the lowest: compounds 2, 1 and 3 (each within the scatter of the next).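

Going from methyl to benzyl gives a 1.6-fold higher number from compound 2 to compound 3 (0.22 log units; within the scatter) in this assay, so compound 2 and compound 3 cannot be told apart. At this place, on a saturated chain carbon bound to an amine nitrogen in a ring, a phenyl of 6 heavy atoms can therefore take the place of hydrogen without a change that this measurement can resolve. Nothing available helps to explain this result.

The compounds shown leave open whether any group at this place can give a number clearly apart from that of compound 2 in this assay. A longer chain ending in phenyl, a phenyl ring carrying a methoxy group, or a carboxylic acid would each test that, and a clear step from any of them would show whether this place matters at all.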